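The source may hold more compounds than are shown below. What is called first, only, known or untested is meant among the compounds shown, and "the series" means these compounds.

Compound 1 `CCOC(=O)C1=Cc2ccccc2OC1(OCc1cn(CC(=O)Nc2cccc(F)c2)nn1)C(F)(F)F` gives > 150000 nM in a functional assay on A549 cells (Homo sapiens) for inhibition, read by MTT assay, with a stated time of 24 h (on this read-out higher numbers stand for weaker inhibition and lower numbers for stronger inhibition), which is a limit of the assay and not a number.
Compound 2 `CCOC(=O)C1=Cc2ccccc2OC1(OCc1cc(-c2ccc(C)cc2)no1)C(F)(F)F` gives > 150000 nM in this assay, again a limit.
Compound 3 `CCOC(=O)C1=Cc2ccccc2OC1(OCc1cc(-c2cccc(C(F)(F)F)c2)no1)C(F)(F)F` gives 48600 nM in this assay.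

On these data alone, compound 1 thus stands at the limit of > 150000 nM in this assay, at which 2 of the 3 values shown sit, so its own number is unknown. Going by the values given here, the only measured step, an at least 3.0-fold lower number from compound 2 to compound 3 (0.48 log units; beyond the scatter), concerns a change on an aromatic carbon and leaves the amide-type nitrogen untouched, so it does not bear on the change at hand. Compound 4 `CCOC(=O)C1=Cc2ccccc2OC1(OCc1cn(CC(=O)NC2CCCCC2)nn1)C(F)(F)F` differs from compound 1 by cyclohexyl in place of 3-fluorophenyl on an amide-type nitrogen. Among the compounds with values here, with no measured step to guide it, compound 4 is expected to stay near the limit, estimated at 150000 nM, within 50000 nM to 300000 nM. The expected step of a number no higher from compound 1 to compound 4 (the limit leaves the size open) is therefore none beyond the scatter.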

Compound 4, half-maximal inhibitory concentration: 9900 nM
The estimate for compound 4 lay 15-fold (1.18 log units) above the measured number; measured number below the stated range.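

In this assay, the amide-type nitrogen proves to be a position that responds: cyclohexyl in place of 3-fluorophenyl gives an at least 15-fold lower number from compound 1 to compound 4 (1.18 log units; beyond the scatter). A non-aromatic ring of carbon only on this nitrogen thus gives a measured number, which the 3-fluorophenyl group does not. Compound 1 has a limit of the assay and not a number, so the full size of the step stays unknown: the limit of > 150000 nM in this assay, at which 2 of the 4 values shown sit.

The compounds shown do not separate the loss of the aromatic ring from the loss of the fluorine. On these data alone, how unsubstituted phenyl, cyclopentyl or a straight hexyl chain would read on this nitrogen stays open.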